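The source may hold more compounds than are shown below. What is called first, only, known or untested is meant among the compounds shown, and "the series" means these compounds.

Measured so far in a functional assay for inhibition, with Homo sapiens as the target; a higher number here means a weaker inhibitor, a lower number a stronger inhibitor:
compound 1 `O=C(O)CCCCCCn1nc(-c2ccccc2)c(-c2ccccc2)c1-c1ccccc1` gives 22400 nM
compound 2 `O=C(O)CCCCCCCCCn1nc(-c2ccccc2)c(-c2ccccc2)c1-c1ccccc1` gives 5500 nM
compound 3 `O=C(O)CS(=O)(=O)CCCCCCn1nc(-c2ccccc2)c(-c2ccccc2)c1-c1ccccc1` gives 22000 nM

Compound 1 has the highest number of the three; compound 3 lies within the scatter of it, and compound 2 is the only one clearly lower. Compound 4 `N#CCCCCCCCCn1nc(-c2ccccc2)c(-c2ccccc2)c1-c1ccccc1` differs from compound 1 as follows: 2-cyanoethyl in place of carboxy on a saturated chain carbon, six bonds along the chain from an aromatic nitrogen. Among the compounds with values here, two measured steps bear on this. a 4.1-fold lower number from compound 1 to compound 2 (0.61 log units; beyond the scatter) shows that a longer chain carrying the acid gave a modest gain. a 1.0-fold lower number from compound 1 to compound 3 (0.01 log units; within the scatter) shows that keeping the acid while altering the chain left the number unchanged. Within the data shown here, compound 4 also lengthens the chain but gives up the carboxy for a nitrile, and no measured step covers that exchange. A modest downward step is expected, smaller than that to compound 2. For compound 4 the expected step is a 2.5-fold lower number from compound 1 to compound 4 (0.40 log units; beyond the scatter). Compound 4 is therefore estimated at 9000 nM, with a range of 3000 nM to 27000 nM.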

Compound 4, half-maximal inhibitory concentration: > 72000 nM
Compound 4: a limit, no number; the forecaster's own chance of this, stated with the estimate: 10%; at least 8.0-fold (0.90 log units) between middle value and limit.
By their numbers in this assay, from the lowest: compound 2; then compounds 3 and 1 (each within the scatter of the next). At a limit, above all of these: compound 4.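

In this assay compound 4 gives no number, only a limit: the limit of > 72000 nM in this assay, at which 1 of the 4 values shown sits. With a nitrile at the chain end, the longer chain no longer lowers the number, as shown by an at least 3.2-fold higher number from compound 1 to compound 4 (0.50 log units; beyond the scatter) and by an at least 3.2-fold higher number from compound 3 to compound 4 (0.51 log units; beyond the scatter). Cyano in place of carboxymethyl on a saturated chain carbon, eight bonds along the chain from an aromatic nitrogen, gives an at least 13-fold higher number from compound 2 to compound 4 (1.11 log units; beyond the scatter), so among these four compounds the lowered number goes with the longer chain and the carboxylic acid together.

As far as these compounds go, whether an amide or a tetrazole at the chain end would hold the number of compound 2 remains open. So does the effect of a still longer chain carrying the carboxylic acid.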